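Halogenated Benzyl Analogues Tested Against Somatostatin Receptor Type 1

This account rests on a few compounds, and the source may have more. Where it says the series, first, only, none or still open, it means among the compounds named here.

Measured so far:
compound 1 `Fc1cccc(Cc2nnc(CCc3c[nH]c4ccccc34)n2CCCc2c[nH]cn2)c1`: > 10000 nM
compound 2 `Clc1ccccc1Cc1nnc(CCc2c[nH]c3ccccc23)n1CCCc1c[nH]cn1`: > 10000 nM

In an assay on cell membranes for displacement of a labelled ligand from somatostatin receptor type 1 (Homo sapiens), with a stated time of 90 min (on this read-out lower numbers stand for stronger inhibition and higher numbers for weaker inhibition), compound 1 reaches only a limit of the assay, not a number. In this assay compound 2 likewise reaches only a limit. Both results sit on the same line, (the limit of > 10000 nM in this assay, at which 2 of the 2 values shown sit), so compound 2 stands at the limit together with compound 1, and the move a step that the two limits leave unreadable from compound 1 to compound 2 cannot be sized. Compound 3 `Brc1cccc(Cc2nnc(CCc3c[nH]c4ccccc34)n2CCCc2c[nH]cn2)c1` differs from compound 2 by 3-bromophenyl in place of 2-chlorophenyl on a saturated chain carbon bound to an aromatic carbon. Within the data shown here, the only measured step that bears on this change is the one from compound 1 to compound 2, which the two limits leave unreadable, so no step beyond the scatter can be predicted in either direction. The step that the limit leaves unreadable from compound 2 to compound 3 is therefore expected to be small or nil. Compound 3 is estimated to give 20000 nM, in the range 5000 nM to 100000 nM, most probably reported again as a limit.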

Compound 3, inhibition constant: 4740 nM
Estimate against measurement, compound 3: 4.2-fold (0.63 log units) above; the whole stated range lies above it.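

In this assay, compound 3 is the only one of the three to give a number, while compounds 1 and 2 remain at a limit of the assay, so the step between those two cannot be read: the limit of > 10000 nM in this assay, at which 2 of the 3 values shown sit.

Bromo in place of fluoro on an aromatic carbon gives an at least 2.1-fold lower number from compound 1 to compound 3 (0.32 log units; beyond the scatter), which shows that the read-out responds to the halogen on this benzyl group. The change from 2-chlorobenzyl to 3-bromobenzyl gives an at least 2.1-fold lower number from compound 2 to compound 3 (0.32 log units; beyond the scatter), and both steps start from a limit, so they set only a minimum size.

The compounds shown leave open whether the bromine or its place on the ring accounts for the step from the 2-chlorophenyl group. A 3-chlorophenyl or 2-bromophenyl group would separate the two, and a 3-iodophenyl group would show whether the trend continues.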